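The compounds below may be only part of what the source reports. "The series", "measured", "known", "first", "only" and "open" are said of these compounds alone.

In a functional assay on MCF7 cells (Homo sapiens) for antiproliferative activity, read by MTT assay, with a stated time of 72 h (on this read-out lower numbers stand for stronger inhibition and higher numbers for weaker inhibition), compound 3 `CCN(c1ccc(O)cc1)S(=O)(=O)C1CC2OC1C(c1ccc(NC(=O)CCCCCCC(=O)O)cc1)=C2c1ccc(O)cc1` gives 46600 nM, the highest number and so the weakest inhibition of the three measured compounds. Compound 1 `CN(c1ccccc1Cl)S(=O)(=O)C1CC2OC1C(c1ccc(NC(=O)CCCCCCC(=O)O)cc1)=C2c1ccc(O)cc1` gives 12800 nM, and compound 2 `CN(c1cccc2ccccc12)S(=O)(=O)C1CC2OC1C(c1ccc(NC(=O)CCCCCCC(=O)O)cc1)=C2c1ccc(O)cc1` gives 14000 nM, a pair within the scatter, as a 1.1-fold higher number from compound 1 to compound 2 (0.04 log units; within the scatter) shows. Compound 4 `CCN(c1ccccc1Br)S(=O)(=O)C1CC2OC1C(c1ccc(NC(=O)CCCCCCC(=O)O)cc1)=C2c1ccc(O)cc1` has 2-bromophenyl in place of 4-hydroxyphenyl on a sulfonamide nitrogen. Two modest measured steps bear on this change: a 3.6-fold higher number from compound 1 to compound 3 (0.56 log units; beyond the scatter) and a 3.3-fold higher number from compound 2 to compound 3 (0.52 log units; beyond the scatter). Compound 1 also carries a halogenated ring, 2-chlorophenyl, so a similar modest step back towards lower numbers is expected in this assay. The expected change is a 3.1-fold lower number from compound 3 to compound 4 (0.49 log units; beyond the scatter). For compound 4, the estimated value is 15000 nM, within an expected range of 7000 nM to 32000 nM.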

Compound 4, half-maximal inhibitory concentration: > 100000 nM
Compound 4 was reported as a limit; the forecaster's own chance of this, stated with the estimate: 3%; middle value at least 6.6-fold (0.82 log units) from the limit.
By their numbers in this assay, from the lowest: compounds 1 and 2 (each within the scatter of the next); then compound 3. At a limit, above all of these: compound 4.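

Compound 4 gives no exact number in this assay, only a limit: the limit of > 100000 nM in this assay, at which 1 of the 4 values shown sits. Even so, 2-bromophenyl on this sulfonamide nitrogen gives weaker inhibition than 4-hydroxyphenyl, with an at least 2.1-fold higher number from compound 3 to compound 4 (0.33 log units; beyond the scatter). A halogenated ring here therefore does not by itself bring the lower numbers seen with compound 1, as shown by an at least 7.8-fold higher number from compound 1 to compound 4 (0.89 log units; beyond the scatter), and the gap remains with an at least 7.1-fold higher number from compound 2 to compound 4 (0.85 log units; beyond the scatter).

From the compounds shown here alone, compound 1 and compound 4 differ in both the halogen and the nitrogen's chain, so which of these matters stays open. (2-Chlorophenyl)(ethyl)amino and (2-bromophenyl)(methyl)amino groups would separate the two.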